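A few compounds are considered here, and "the series" means these few. Any claim that something is new, unique, unknown or untested is made for them only; others in the source may bear on it.

Measured compounds:
compound 1, `COc1cc(Cl)cc(-c2nn(-c3cccc(NC(=O)Nc4ccc(Cl)c(C(F)(F)F)c4)c3)cc2-c2ccncc2)c1`, which in a functional assay on SK-MEL-28 cells (Homo sapiens) for inhibition, read by sulforhodamine B assay, with a stated time of 48 h, tested at 10 uM (a lower number here means a stronger effect, a higher number a weaker effect of the compound at the concentration tested), gives for compound 1 23.6%
compound 3, `COc1cc(Cl)cc(-c2nn(-c3cccc(NC(=O)Nc4ccc(Cl)c(Cl)c4)c3)cc2-c2ccncc2)c1`, which in this assay gives for compound 3 23.2%
compound 2, `COc1cc(Cl)cc(-c2nn(-c3cccc(NC(=O)Nc4cc(C(F)(F)F)cc(C(F)(F)F)c4)c3)cc2-c2ccncc2)c1`, which in this assay gives for compound 2 6.55%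

Compound 3 stands second highest of these three numbers. Its nearest neighbour is compound 1, whose number sits higher by an amount within the scatter, so the two are not distinguished here. The furthest from it is compound 2, whose number lies beyond the scatter below that of compound 3, so compound 2 shows the stronger effect of the two.

Compound 4, `COc1cc(Cl)cc(-c2nn(-c3cccc(NC(=O)Nc4cccc(C(F)(F)F)c4)c3)cc2-c2ccncc2)c1`, is not yet measured. It differs from compound 3 in one place: 3-(trifluoromethyl)phenyl in place of 3,4-dichlorophenyl on an amide-type nitrogen. Within the data shown here, the only measured step between compounds differing in one place is a number 0.4 percentage points lower from compound 1 to compound 3 (within the scatter), and it touches the same part of the molecule as the change to compound 4, but it exchanges one group for another rather than removing one. Compound 2 differs from compound 4 in more than one place, so only its value can be set beside the others, and it carries the lowest number shown.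

On this basis a step of a number 6.8 percentage points higher from compound 3 to compound 4 (within the scatter) is expected, most likely a number somewhat higher than that of compound 3, though a result within the scatter would not be surprising. For compound 4 the expected value is 30%, with a range from 12% to 50%.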

Compound 4, a percentage reported as activity, at one concentration (the size of the read-out at that concentration, not a potency): 14.1%
The estimate for compound 4 lay 15.9 percentage points above the measured number; the measured number falls inside the stated range.
By their numbers in this assay, from the lowest: compounds 2, 4, 3 and 1 (each within the scatter of the next, the first and the last beyond it).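

In this assay, hydrogen in place of chloro on an aromatic carbon gives a number 9.5 percentage points lower from compound 1 to compound 4 (within the scatter) and hydrogen in place of trifluoromethyl gives a number 7.6 percentage points higher from compound 2 to compound 4 (within the scatter) in this series. These are the first steps shown that remove a group from the aromatic ring on the amide-type nitrogen rather than exchange one group for another, and neither removal gives a change that stands clear of the scatter, so a ring carrying 3-(trifluoromethyl) alone is not distinguished from the more heavily substituted rings at this concentration. Exchanging 3,4-dichlorophenyl for 3-(trifluoromethyl)phenyl gives a number 9.1 percentage points lower from compound 3 to compound 4 (within the scatter) and likewise leaves the two compounds undistinguished, while no independent measurement is available that could account for any of these steps.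

The compounds shown leave open whether a group of another kind on this ring, such as a nitrile, a methoxy or a dimethylamino group, would give a step beyond the scatter. They also leave open how the ring would behave with no group on it at all, and whether these ureas would differ in the strength of their effect at other concentrations.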